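Swapping a ring for a chain-linked ring on the pyridine

The source may report more compounds than this note shows. Statements on the series, on what has been measured and on what is new or still open speak of the compounds shown alone.

Of the compounds shown here, two have been measured in an assay on CHO cells for antagonist activity at transient receptor potential cation channel subfamily V member 1 (Homo sapiens), read by FLIPR and calcium flux; on this read-out lower numbers stand for stronger inhibition and higher numbers for weaker inhibition. Compound 1, `CCCCCCc1nc(C(F)(F)F)ccc1CNC(=O)C(C)c1ccc(NS(C)(=O)=O)c(F)c1`, carries a hexyl chain on the shared core and gives 1.6 nM. Compound 2, `CC1C=C(c2nc(C(F)(F)F)ccc2CNC(=O)C(C)c2ccc(NS(C)(=O)=O)c(F)c2)CCC1`, carries a 3-methylcyclohex-1-en-1-yl group in the same position and gives 0.2 nM. Going by the values given here, the single change between them, an 8.0-fold lower number from compound 1 to compound 2 (0.90 log units; beyond the scatter), shows that replacing the straight chain by the ring-bearing group gave a clearly stronger result, placing compound 2 at the lowest of the two numbers so far.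

Compound 3, `CC(C(=O)NCc1ccc(C(F)(F)F)nc1/C=C/C1CCCCC1)c1ccc(NS(C)(=O)=O)c(F)c1`, is the next step: 2-cyclohexylethenyl in place of 3-methylcyclohex-1-en-1-yl on an aromatic carbon. Here the ring is no longer attached directly to the core but is carried on a two-carbon double-bonded linker, and it lacks the methyl group. Among the compounds with values here, no measured step covers this kind of change. Within the data shown here, the only guidance is that both compound 1 and compound 2 bind strongly, so a large loss seems unlikely; a small loss or no change beyond the scatter is the more probable outcome.

Compound 3 is therefore expected to give about 0.5 nM, somewhere between 0.1 nM and 2.5 nM, meaning an estimated step of a 2.5-fold higher number from compound 2 to compound 3 (0.40 log units; beyond the scatter).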

Compound 3, inhibition constant: 0.7 nM
The estimate for compound 3 lay 1.4-fold (0.15 log units) below the measured number; the range from low to high includes it.
By their numbers in this assay, from the lowest: compound 2; then compound 3; then compound 1.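

At this position on the shared core, the group does not have to be 3-methylcyclohex-1-en-1-yl to give a low number in this assay, although the switch to 2-cyclohexylethenyl still costs something, with a 3.5-fold higher number from compound 2 to compound 3 (0.54 log units; beyond the scatter). The new group keeps much of the gain over the open chain, with a 2.3-fold lower number from compound 1 to compound 3 (0.36 log units; beyond the scatter), so both groups that carry a six-membered ring give lower numbers than hexyl, and none of the three compounds goes against this. No supporting data explain this order among the three groups.

The step from compound 2 to compound 3 changes several things at once: the methyl group goes, the double bond moves out of the ring, and the ring is held further from the aromatic carbon, so the compounds shown cannot say which of these matters. Going by these compounds, what a cyclohexyl group attached directly, a phenyl ring or an amine would give on this aromatic carbon also remains open.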